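Chloro to trifluoromethyl on the shared core: stability notes

A few compounds are considered here, and "the series" means these few. Any claim that something is new, unique, unknown or untested is made for them only; others in the source may bear on it.

Compound 1 `CC(=O)N1CCN(c2cc(-c3cc(Cl)c4c(N)ncnn34)ccc2C(F)(F)F)C(=O)C1(C)C`, compound 2 `CC(=O)N1CCN(c2cc(-c3cc(Cl)c4c(N)ncnn34)ccc2Cl)C(=O)C1(C)C` and compound 3 `CC(=O)N1C[C@@H](C)N(c2cc(-c3cc(Cl)c4c(N)ncnn34)ccc2C#N)C(=O)C1(C)C` are measured; compound 4 `CC(=O)N1C[C@@H](C)N(c2cc(-c3cc(C(F)(F)F)c4c(N)ncnn34)ccc2C#N)C(=O)C1(C)C` is not. In an ADME assay on microsomes from liver (Rattus norvegicus) for metabolic stability, read by LC-MS, using NADPH, with stated times of 6 min and 10 min, tested at 0.5 uM (a higher number here means that more of the compound is left, a lower number that less of the compound is left), compound 1 gives 87%, compound 2 gives 52% and compound 3 gives 59%. The change trifluoromethyl in place of chloro on an aromatic carbon makes a number 35 percentage points higher from compound 2 to compound 1 (beyond the scatter). The same kind of change, (trifluoromethyl in place of chloro on an aromatic carbon), takes compound 3 to compound 4, here on a five-membered aromatic ring with one nitrogen in a fused or bridged system rather than on a six-membered ring of carbon only, ortho and para to a large group. The difference between the cores of compound 2 and compound 3 is not broken down here. Because of a number 35 percentage points higher from compound 2 to compound 1 (beyond the scatter), a higher number is expected for compound 4, with a number 19 percentage points higher from compound 3 to compound 4 (beyond the scatter) tempered by the different place. Compound 4 is estimated at 78%, between 62% and 92%.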

Compound 4, percent of the compound remaining: 43%
For compound 4 the middle estimate is 35 percentage points above the measured one; the measured number lies below the stated range.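

In this assay, trifluoromethyl in place of chloro on an aromatic carbon gives a number 16 percentage points lower from compound 3 to compound 4 (beyond the scatter). In this series the change does not carry from one core to another with a fixed size or even a fixed direction: the same change on two cores in this assay, a number 35 percentage points higher (beyond the scatter) from compound 2 to compound 1 and a number 16 percentage points lower (beyond the scatter) from compound 3 to compound 4, 51 percentage points apart, beyond the scatter of two such steps. The two steps differ both in the place of the change, a six-membered ring of carbon only against a five-membered aromatic ring with 1 nitrogen, and in the rest of the core, so the two cases do not show which of these sets the direction.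

Still open, on these data alone, is how a fluoro or methoxy group would behave on that five-membered ring. Also open, as far as these compounds go, is whether the change on that ring would go the same way on the core of compound 1.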